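Compound 4 from Compound 3: Furan to Cyanophenyl

This account rests on a few compounds, and the source may have more. Where it says the series, first, only, none or still open, it means among the compounds named here.

Compound 3 `Nc1nc(-c2ccc(Cl)o2)nc2sc(CN3CCC(F)CC3)cc12` gives 1080 nM in an assay on CHO-K1 cells for antagonist activity at adenosine receptor A1 (Homo sapiens), read by a beta-galactosidase reporter, with stated times of 15 min and 6 h; a lower number here means a stronger inhibitor, a higher number a weaker inhibitor. Compound 1 `Nc1nc(-c2ccco2)nc2sc(CN3CCC(F)CC3)cc12` gives 740 nM and compound 2 `Nc1nc(-c2ccc(Cl)o2)nc2sc(CN3CCCCCC3)cc12` gives 1420 nM, so compound 3 sits within the scatter of both, as the steps of a 1.5-fold higher number from compound 1 to compound 3 (0.16 log units; within the scatter) and a 1.3-fold lower number from compound 2 to compound 3 (0.12 log units; within the scatter) show. Compound 4 `N#Cc1cccc(-c2nc(N)c3cc(CN4CCC(F)CC4)sc3n2)c1` differs from compound 3 by 3-cyanophenyl in place of 5-chlorofuran-2-yl on an aromatic carbon. Among the compounds with values here, no measured step touches this position; the two steps that exist concern the chloro group and the saturated chain carbon, and both left the number within the scatter. The data give no direct guide, so the expected step is a 1.1-fold lower number from compound 3 to compound 4 (0.03 log units; within the scatter), with a wide range. The estimate for compound 4 is 1000 nM, between 250 nM and 4000 nM.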

Compound 4, inhibition constant: 2950 nM
Beside the measured number, compound 4's estimate is 3.0-fold (0.47 log units) below it, and the stated range covers the measured number.
By their numbers in this assay, from the lowest: compounds 1, 3 and 2 (each within the scatter of the next); then compound 4.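

In this assay this position is the first shown where a change goes beyond the scatter: 3-cyanophenyl in place of 5-chlorofuran-2-yl gives a 2.7-fold higher number from compound 3 to compound 4 (0.44 log units; beyond the scatter) and 3-cyanophenyl in place of furan-2-yl gives a 4.0-fold higher number from compound 1 to compound 4 (0.60 log units; beyond the scatter). The chloro group made no difference beyond the scatter, yet replacing either furan with the six-membered aromatic ring of carbon only raised the number. Nothing measured here accounts for this step.

The compounds shown leave open whether the step follows from the ring itself or from its nitrile. A plain phenyl or a thiophen-2-yl group on this aromatic carbon would bear on that question.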